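The compounds below may be only part of what the source reports. "The series", "measured", "known", "first", "only" and "open" are said of these compounds alone.

Of the compounds shown here, three that share one core have been tested. Compound 1 `Cc1cc(OCC2=NCCO2)ccc1Cl` in a functional assay on the whole organism for inhibition, with Rattus norvegicus as the target, read by paw edema, with a stated time of 30 min, at a dose of 20 mg/kg by the oral route (on this read-out lower numbers stand for a weaker effect and higher numbers for a stronger effect at the one dose given), gives 22.2%. Compound 2 `Cc1cccc(OCC2=NCCO2)c1` in this assay gives 16.6%. Compound 3 `Fc1ccccc1OCC1=NCCO1` in this assay gives 20.6%. Compound 2 carries the lowest of these three numbers, yet its distance to compound 3 and to compound 1 lies within the scatter of repeated measurements, so the three cannot be told apart on this read-out.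

For the measured compounds named here, only one pair differs in a single place: a number 5.6 percentage points lower from compound 1 to compound 2 (within the scatter), a step within the scatter.

Compound 4 `O=[N+]([O-])c1cccc(OCC2=NCCO2)c1` differs from compound 2 in one place: nitro in place of methyl on an aromatic carbon. Going by the values given here, no measured step exchanges a methyl for a nitro, so nothing directly tells what this exchange does. Among the compounds with values here, the one step that is known, the loss of a chloro between compound 1 and compound 2, left the read-out within the scatter, and all three measured numbers sit close together. On that basis the expected step is a number 1.4 percentage points higher from compound 2 to compound 4 (within the scatter), that is, no movement beyond the scatter. Compound 4 is therefore estimated at 18%, with a range from 5% to 33%.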

Compound 4, a percentage reported as inhibition, in the whole organism at one dose (the size of the read-out at that dose, not a potency): 15.5%
Beside the measured number, compound 4's estimate is 2.5 percentage points above it; measured number inside the range.
By their numbers in this assay, from the lowest: compounds 4, 2, 3 and 1 (each within the scatter of the next).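

Replacing the methyl on this aromatic carbon with nitro gives a number 1.1 percentage points lower from compound 2 to compound 4 (within the scatter) in this assay and so does not separate the two groups on this read-out. The earlier compounds shown here showed only the loss of a chloro, whereas this change swaps 1 heavy atom with no hydrogen-bond acceptors for 3 heavy atoms with 2 hydrogen-bond acceptors, and the read-out still stays within the scatter. No measurement at hand bears on why this is so.

On these data alone, whether any group at this place can move the number beyond the scatter remains open, for example an amine, a carboxylic acid or a longer chain such as butyl. Because each number comes from one dose, the compounds shown also leave open whether methyl and nitro would still look alike at other doses.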